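Replacing a vinylsulfonylamino group on a shared anilide core

The compounds below may be only part of what the source reports. "The series", "measured", "known", "first", "only" and "open" are said of these compounds alone.

The three measured compounds share a common core and differ only in the substituent carried on the benzamide side. Compound 1, `C=CS(=O)(=O)NCc1ccc(C(=O)Nc2ccc(C)c(Nc3nccc(-c4cccnc4)n3)c2)cc1`, gives 7710 nM in an ADME assay on BaF3 cells (Mus musculus) for cytotoxicity, read by CellTiter-Glo and CCK-8 assay, with a stated time of 72 h (on this read-out lower numbers stand for stronger inhibition of growth and higher numbers for weaker inhibition of growth), and this stands as the highest of the three numbers. Compound 3, `C=CC(=O)Nc1cc(C(=O)Nc2ccc(C)c(Nc3nccc(-c4cccnc4)n3)c2)cc(C(F)(F)F)c1`, gives 5460 nM, and compound 2, `CCC(=O)NCc1cccc(C(=O)Nc2ccc(C)c(Nc3nccc(-c4cccnc4)n3)c2)c1`, gives 4750 nM; both of these lie within the scatter of the value of compound 1, so the three compounds are not separated by this read-out.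

Compound 4, `Cc1ccc(NC(=O)c2ccc(CN(CCN(C)C)C(=O)C(C)C)cc2)cc1Nc1nccc(-c2cccnc2)n1`, has not yet been measured. It differs from compound 1 in one place: (2-(dimethylamino)ethyl)(isopropylcarbonyl)amino in place of (vinylsulfonyl)amino on a saturated chain carbon bound to an aromatic carbon. For the measured compounds named here, no measured pair shows this change, so its effect is unknown from the data. Given that all three measured compounds sit close together, the step from compound 1 to compound 4 is expected to be small, a 1.2-fold higher number from compound 1 to compound 4 (0.07 log units; within the scatter), and no direction beyond the scatter is predicted. Compound 4 is therefore expected to give about 9000 nM, within a range from 3500 nM to 25000 nM.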

Compound 4, concentration for 50% growth inhibition: > 10000 nM
Compound 4: only a limit was reported; the forecaster's own chance of this, stated with the estimate: 20%; middle value at least 1.1-fold (0.04 log units) from the limit.
By their numbers in this assay, from the lowest: compounds 2, 3 and 1 (each within the scatter of the next). At a limit, above all of these: compound 4.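

In this assay, compound 4 reaches a limit of the assay, > 10000 nM, and this is not a measured number. The exchange of (vinylsulfonyl)amino for (2-(dimethylamino)ethyl)(isopropylcarbonyl)amino on a saturated chain carbon bound to an aromatic carbon gives the first step read at this position, an at least 1.2-fold higher number from compound 1 to compound 4 (0.11 log units; that floor lies within the scatter), so this change brings no stronger inhibition of growth, though whether it weakens inhibition remains unsettled. The step can be read only as a floor because compound 4 stands at the limit: the limit of > 10000 nM in this assay, at which 1 of the 4 values shown sits.

The compounds shown leave open whether the dimethylamino end or the isopropylcarbonyl group alone would give the same result, as the two enter together. They also leave open whether a simple primary amine or a carboxylic acid at this place would give a lower number.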